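From 2-methylphenyl to 4-phenylphenyl on a carbonyl carbon

A few compounds are considered here, and "the series" means these few. Any claim that something is new, unique, unknown or untested is made for them only; others in the source may bear on it.

Compound 1 `CCCCCCOc1ccc(C(=O)/C=C/c2c(/C=C/c3ccc(OC)cc3)cc(OC)cc2OC)cc1` gives 8.4 ug/mL
Compound 2 `COc1ccc(/C=C/c2cc(OC)cc(OC)c2/C=C/C(=O)c2ccccc2C)cc1` gives 5.9 ug/mL

Both values come from a functional assay on A549 cells (Homo sapiens) for antiproliferative activity, read by MTT assay, with a stated time of 48 h (a higher number here means a weaker inhibitor, a lower number a stronger inhibitor), and compound 2 lies within the usual scatter of compound 1. Compound 3 `COc1ccc(/C=C/c2cc(OC)cc(OC)c2/C=C/C(=O)c2ccc(-c3ccccc3)cc2)cc1` differs from compound 2 in one place: 4-phenylphenyl in place of 2-methylphenyl on a carbonyl carbon. Going by the values given here, no measured pair shows this change directly, so the evidence is thin, and compound 1 at 8.4 ug/mL and compound 2 at 5.9 ug/mL offer only a narrow spread. No clear direction is expected in this assay and the expected step of a 1.0-fold higher number from compound 2 to compound 3 (0.01 log units; within the scatter) stays within the scatter. For compound 3 the estimated value is 6 ug/mL with an expected range from 2.5 ug/mL to 14 ug/mL.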

Compound 3, half-maximal inhibitory concentration: 4.6 ug/mL
The estimate for compound 3 lay 1.3-fold (0.12 log units) above the measured number, and the stated range covers the measured number.
By their numbers in this assay, from the lowest: compounds 3, 2 and 1 (each within the scatter of the next).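

In this assay, 4-phenylphenyl in place of 2-methylphenyl on the carbonyl carbon gives a 1.3-fold lower number from compound 2 to compound 3 (0.11 log units; within the scatter), so this position holds a group with a second aromatic ring without any readable change. Phenyl in place of hexyloxy on an aromatic carbon gives a 1.8-fold lower number from compound 1 to compound 3 (0.26 log units; within the scatter), again no readable change. No measurement shown here speaks to why these numbers stay so close.

From the compounds shown here alone, what an amine or a carboxylic acid on that carbonyl carbon would do remains open. So does whether any change at either place can move the number beyond the scatter.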